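A few compounds are considered here, and "the series" means these few. Any claim that something is new, unique, unknown or untested is made for them only; others in the source may bear on it.

In a physicochemical assay for lipophilicity, measured as octanol-water partition (on this read-out higher numbers stand for higher lipophilicity and lower numbers for lower lipophilicity), compound 1 (`O=C(NNc1ccnc2cc(Cl)ccc12)c1ccccc1/N=C/c1ccc(Cl)cc1Cl`) gives 6.22 and compound 2 (`N#Cc1ccc(/C=N/c2ccccc2C(=O)NNc2ccnc3cc(Cl)ccc23)cc1`) gives 4.83 as the lower of the two numbers. Compound 3 (`CN(C)c1ccc(/C=N/c2ccccc2C(=O)NNc2ccnc3cc(Cl)ccc23)cc1`) differs from compound 2 in one place (dimethylamino in place of cyano on an aromatic carbon) with dimethylamino in place of cyano on an aromatic carbon. Within the data shown here, the one measured step (a number 1.39 log units lower from compound 1 to compound 2 (beyond the scatter)) was large and brought in the same 4-cyanophenyl group that now leaves, yet no measured compound carries dimethylamino. Set against that step, a smaller upward change is expected in this assay (a number 0.67 log units higher from compound 2 to compound 3 (beyond the scatter)) with wide margins. For compound 3 the estimate is 5.5 with an expected range from 5 to 6 at this stage.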

Compound 3, partition coefficient: 5.03
Estimate against measurement, compound 3: 0.47 log units above; the range from low to high includes it.
By their numbers in this assay, from the lowest: compounds 2 and 3 (each within the scatter of the next); then compound 1.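

In this assay, dimethylamino in place of cyano on this aromatic carbon gives a number 0.20 log units higher from compound 2 to compound 3 (within the scatter), so the two groups cannot be told apart at this place on this read-out. The step to 4-(dimethylamino)phenyl from 2,4-dichlorophenyl gives a number 1.19 log units lower from compound 1 to compound 3 (beyond the scatter), which leaves compound 1 apart from both compound 2 and compound 3. Nothing available accounts for these numbers. Still open, as far as these compounds go, is whether a carboxylic acid or a longer alkyl chain on the same aromatic carbon would stay with compound 2 and compound 3 or move toward compound 1.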